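From Bromo to Fluoro on the Shared Core

The compounds below may be only part of what the source reports. "The series", "measured", "known", "first", "only" and "open" are said of these compounds alone.

Measured in a functional assay on HEp-2 cells (Homo sapiens) for inhibition; a higher number here means a weaker inhibitor, a lower number a stronger inhibitor:
- Compound 1 `O=C1O/C(=C\Cn2cc(C(F)(F)F)c(=O)[nH]c2=O)C(OCc2ccccc2)=C1OCc1ccccc1`: 40000 nM
- Compound 2 `O=C1O/C(=C\Cn2cc(I)c(=O)[nH]c2=O)C(OCc2ccccc2)=C1OCc1ccccc1`: 10000 nM
- Compound 3 `O=C1O/C(=C\Cn2cc(Br)c(=O)[nH]c2=O)C(OCc2ccccc2)=C1OCc1ccccc1`: 90000 nM

Among these three, compound 3 is the weakest inhibitor in this assay, at 90000 nM. Compound 4 `O=C1O/C(=C\Cn2cc(F)c(=O)[nH]c2=O)C(OCc2ccccc2)=C1OCc1ccccc1` carries fluoro in place of bromo on an aromatic carbon. Among the measured compounds shown here, no fluoro compound has been measured yet, so the closest evidence comes from two other changes at this same carbon. These are a 2.3-fold higher number from compound 1 to compound 3 (0.35 log units; beyond the scatter) and a 9.0-fold higher number from compound 2 to compound 3 (0.95 log units; beyond the scatter). Both are modest, and the trifluoromethyl compound lies between the two halogen compounds, so the three values give no simple order to extend to fluoro. Both other groups measured at this carbon give a lower number than bromo, so a modest drop is expected on leaving bromo, with considerable uncertainty. The expected change is a 3.6-fold lower number from compound 3 to compound 4 (0.56 log units; beyond the scatter). Compound 4 is estimated at 25000 nM, with an expected range from 3000 nM to 100000 nM.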

Compound 4, half-maximal inhibitory concentration: 20000 nM
Compound 4: the middle estimate sits 1.3-fold (0.10 log units) above what was measured; low and high end bracket the measured number.
By their numbers in this assay, from the lowest: compounds 2, 4 and 1 (each within the scatter of the next, the first and the last beyond it); then compound 3.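

In this assay, among the compounds shown here, the new step (a 4.5-fold lower number from compound 3 to compound 4 (0.65 log units; beyond the scatter)) leaves bromo as the one group at this carbon set apart from all the others, and compound 3 is the weakest inhibitor of the four. Fluoro cannot be separated from either iodo (a 2.0-fold higher number from compound 2 to compound 4 (0.30 log units; within the scatter)) or trifluoromethyl (a 2.0-fold lower number from compound 1 to compound 4 (0.30 log units; within the scatter)), even though compound 1 and compound 2 differ from each other beyond the scatter. The three halogens therefore form no steady order from fluoro through bromo to iodo, with compound 3 going against one, and nothing available here accounts for this.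

Going by these compounds, it remains open whether a methyl, a nitrile or an amine at this carbon would give a number like that of bromo or like those of fluoro and iodo. On these data alone, it is also open whether the exceptional standing of bromo would persist if the benzyl ethers on the shared core were replaced by free hydroxyl groups.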